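The source may report more compounds than this note shows. Statements on the series, on what has been measured and on what is new or still open speak of the compounds shown alone.

Compound 2 `COC(=O)c1sc2cc(C#Cc3ccccc3)cnc2c1N` carries the shared core with an unsubstituted phenyl on its alkyne arm. In a functional assay on NCI-H460 cells (Homo sapiens) for inhibition, read by sulforhodamine B assay, with a stated time of 48 h (a higher number here means a weaker inhibitor of growth, a lower number a stronger inhibitor of growth), compound 2 gives > 150000 nM, and this figure is a limit of the assay rather than a measured number. Its close relative compound 1 `COC(=O)c1sc2cc(C#Cc3ccccc3F)cnc2c1N` differs only in bearing a fluoro on that phenyl. In this assay compound 1 gives > 150000 nM, again a limit and not a number. The step that the two limits leave unreadable from compound 1 to compound 2 therefore cannot be read in size or direction, since both ends rest on the same limit (the limit of > 150000 nM in this assay, at which 2 of the 2 values shown sit). Compound 3 `COC(=O)c1sc2cc(C#Cc3ccc(F)cc3)cnc2c1N` is the next compound. Relative to compound 2 the change is fluoro in place of hydrogen on an aromatic carbon. For the measured compounds named here, the only measured step that bears on this change, the one between compound 1 and compound 2, is unreadable, so the evidence gives no ground for a shift in this assay beyond the scatter in either direction. Compound 3 is thus expected to remain at the limit, with an estimate of 200000 nM and a range from 60000 nM to 600000 nM. The step this implies, a step that the limit leaves unreadable from compound 2 to compound 3, is expected to be no more than the scatter.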

Compound 3, concentration for 50% growth inhibition: 24000 nM
For compound 3 the middle estimate is 8.3-fold (0.92 log units) above the measured one, and the stated range ends above it.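

Among the three compounds, only compound 3 gives a measured number in this assay, where compound 3 reaches 24000 nM, so this arm can carry growth inhibition once the phenyl bears a fluoro para to a large group. Fluoro in place of hydrogen at that place gives an at least 6.2-fold lower number from compound 2 to compound 3 (0.79 log units; beyond the scatter), while 4-fluorophenyl in place of 2-fluorophenyl gives an at least 6.2-fold lower number from compound 1 to compound 3 (0.79 log units; beyond the scatter), which shows that the place of the fluoro on the ring counts and not just its presence, with compound 1 going against any rule that fluoro on this phenyl is enough. Both steps give only a minimum size and not a true one because each starts from a compound at a limit of the assay: the limit of > 150000 nM in this assay, at which 2 of the 3 values shown sit.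

The compounds shown leave open whether fluoro itself matters at this place, or whether chloro, methoxy or an amine there would give a similar or lower number. They also leave open whether a larger change to the arm, such as a pyridine in place of the 4-fluorophenyl, would keep the growth inhibition seen with compound 3.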